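A few compounds are considered here, and "the series" means these few. Any claim that something is new, unique, unknown or untested is made for them only; others in the source may bear on it.

Values so far in an assay on isolated protein for inhibition of Nicotinamide N-methyltransferase (Homo sapiens), read by luminescence, with a stated time of 20 min; on this read-out higher numbers stand for weaker inhibition and lower numbers for stronger inhibition:

compound 1 `C[C@@H]1Cc2cc(C(N)=O)c[n+](C)c2N1`: 6240 nM
compound 2 `CNc1cc(Cl)c(C(N)=O)cn1`: 639 nM
compound 3 `CNc1cc(C)c(C(N)=O)cn1`: 282 nM

Compound 3 carries the lowest number of the three in this assay. Its nearest neighbour is compound 2: the step of a 2.3-fold lower number from compound 2 to compound 3 (0.36 log units; beyond the scatter) is modest but beyond the scatter. Within the data shown here, compound 1, built on a different core, lies far above both; no single-change step connects it to the others, so its value is only a point of reference here.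

Compound 4 `CNc1cc(OC)c(C(N)=O)cn1` differs from compound 3 by methoxy in place of methyl on an aromatic carbon. Among the measured compounds shown here, the only measured step at this position is a 2.3-fold lower number from compound 2 to compound 3 (0.36 log units; beyond the scatter), which shows that exchanging the group here can move the number, but only modestly. For the measured compounds named here, no measured compound carries a methoxy anywhere, so nothing in the set shows which way a methyl-to-methoxy exchange would turn, and the reference step gives only a sense of scale. The working assumption is a step of at most the size seen between compound 2 and compound 3, in either direction.

Compound 4 is therefore expected to give about 300 nM in this assay, with a range of 100 nM to 900 nM. The expected step of a 1.1-fold higher number from compound 3 to compound 4 (0.03 log units; within the scatter) is estimated to stay within the usual scatter.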

Compound 4, half-maximal inhibitory concentration: > 10000 nM
Compound 4: a limit, no number (the forecaster's own chance of this, stated with the estimate: 2%); middle value at least 33-fold (1.52 log units) away from the limit.
By their numbers in this assay, from the lowest: compound 3; then compound 2; then compound 1. At a limit, above all of these: compound 4.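

In this assay compound 4 gives > 10000 nM, which is a limit of the assay and not a number: the limit of > 10000 nM in this assay, at which 1 of the 4 values shown sits.

Among these compounds, this place, opposite the ring nitrogen, proves far more sensitive than the only earlier step, a 2.3-fold lower number from compound 2 to compound 3 (0.36 log units; beyond the scatter), could show: methoxy in place of methyl brings an at least 35-fold higher number from compound 3 to compound 4 (1.54 log units; beyond the scatter), and methoxy in place of chloro brings an at least 15-fold higher number from compound 2 to compound 4 (1.19 log units; beyond the scatter). Among the three groups at this place, chloro in compound 2 and methyl in compound 3 both keep a measured value, whereas methoxy in compound 4 gives no number, so the exchange of one group here can decide whether a value is obtained at all, not merely shift it modestly.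

Still open, on these data alone, is whether this loss follows the oxygen of methoxy or the added carbon beyond it, a question that a hydroxyl, an ethyl or a fluoro at the same place would help to separate. Also open, as far as these compounds go, is how far compound 4 actually lies beyond the limit, and so the true size of both new steps.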